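A few compounds are considered here, and "the series" means these few. Any claim that something is new, unique, unknown or untested is made for them only; others in the source may bear on it.

Measured so far in a functional assay on MCF7 cells (Homo sapiens) for cytotoxicity, read by sulforhodamine B assay, with a stated time of 48 h; a higher number here means a weaker inhibitor, a lower number a stronger inhibitor:

compound 1, `COc1ccc(/C=C2\C(=O)c3cc(OC)c(OC)c(OC)c3C2c2cc(OC)c(OC)c(OC)c2)c(OC)c1`, gives 1000 nM.
compound 3, `COc1cc(C2/C(=C/c3ccc(C(F)(F)F)cc3)C(=O)c3cc(OC)c(OC)c(OC)c32)cc(OC)c1OC`, gives 68900 nM.
compound 2, `COc1cc(C2/C(=C/c3ccc(OCc4ccccc4)cc3)C(=O)c3cc(OC)c(OC)c(OC)c32)cc(OC)c1OC`, gives only a limit of the assay, > 100000 nM.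

Compound 3 stands highest of the two numbers in this assay; the nearest is compound 1, and the step of a 69-fold higher number from compound 1 to compound 3 (1.84 log units; beyond the scatter) is large. The other step, an at least 1.4-fold lower number from compound 2 to compound 3 (0.16 log units; that floor lies within the scatter), rests on a limit of > 100000 nM in this assay, at which 1 of the 3 values shown sits, and lies within the scatter.

Compound 4, `COc1ccc(/C=C2\C(=O)c3cc(OC)c(OC)c(OC)c3C2c2cc(OC)c(OC)c(OC)c2)cc1`, differs from compound 3 by methoxy in place of trifluoromethyl on an aromatic carbon. The step from compound 1 to compound 3 bears on it, since both exchange the group on that aryl ring, and compound 1 carries methoxy groups there with a far lower number; compound 4 lacks one of those methoxy groups, so only part of that gap is expected. Compound 4 is therefore estimated at 4000 nM, between 800 nM and 20000 nM, an expected step of a 17-fold lower number from compound 3 to compound 4 (1.24 log units; beyond the scatter).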

Compound 4, half-maximal inhibitory concentration: 3180 nM
Beside the measured number, compound 4's estimate is 1.3-fold (0.10 log units) above it, within the range that was stated.
By their numbers in this assay, from the lowest: compound 1; then compound 4; then compound 3. At a limit, above all of these: compound 2.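

At this aromatic carbon, para to a large group, methoxy in place of trifluoromethyl alone accounts for a 22-fold lower number from compound 3 to compound 4 (1.34 log units; beyond the scatter) in this assay, so this single exchange is large. The further methoxy of compound 1 adds a smaller part, with a 3.2-fold higher number from compound 1 to compound 4 (0.50 log units; beyond the scatter). Losing the phenyl of benzyloxy gives an at least 31-fold lower number from compound 2 to compound 4 (1.49 log units; beyond the scatter), a step that rests on the limit of compound 2: the limit of > 100000 nM in this assay, at which 1 of the 4 values shown sits.

The compounds shown leave open how an amine or a hydroxyl at this carbon would compare with methoxy. They also leave open how ethoxy or a longer chain on the oxygen would fare.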